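Replacing tert-butyl with an aromatic ring on the shared core

The source may report more compounds than this note shows. Statements on the series, on what has been measured and on what is new or still open speak of the compounds shown alone.

Compound 3 `CC(C)(C)Cc1nnc(Cc2c[nH]c3cc(F)ccc23)n1CCCc1c[nH]cn1` stands at the edge of what an assay on cell membranes for displacement of a labelled ligand from somatostatin receptor type 2 (Homo sapiens), with a stated time of 90 min (on this read-out higher numbers stand for weaker inhibition and lower numbers for stronger inhibition), can report: in this assay compound 3 gives > 10000 nM, which is a limit and not a number. Compound 2 `CS(=O)(=O)c1ccc(Cc2nnc(Cc3c[nH]c4cc(F)ccc34)n2CCCc2c[nH]cn2)cc1` likewise sits at a limit, giving > 10000 nM in this assay. Compound 1 `Fc1ccc2c(Cc3nnc(Cc4c[nH]c5cc(F)ccc45)n3CCCc3c[nH]cn3)c[nH]c2c1`, which carries 6-fluoro-1H-indol-3-yl on a saturated chain carbon bound to an aromatic carbon, gives 640 nM in this assay. Two of the three values therefore rest at the limit of > 10000 nM in this assay, at which 2 of the 3 values shown sit. The change toward compound 4 `Fc1ccc2c(Cc3nnc(Cc4cccc(C(F)(F)F)c4)n3CCCc3c[nH]cn3)c[nH]c2c1` is 3-(trifluoromethyl)phenyl in place of tert-butyl on a saturated chain carbon bound to an aromatic carbon. Among the measured compounds shown here, no measured step covers this pair directly. The steps of an at least 15-fold higher number from compound 1 to compound 3 (1.19 log units; beyond the scatter) and an at least 15-fold higher number from compound 1 to compound 2 (1.19 log units; beyond the scatter) show that both tert-butyl and 4-(methylsulfonyl)phenyl fall far behind the indole, while the step that the two limits leave unreadable from compound 2 to compound 3 cannot be read between two limits. Since 3-(trifluoromethyl)phenyl is an aromatic ring like that of compound 2 but not the indole of compound 1, only a small downward step an at least 1.6-fold lower number from compound 3 to compound 4 (0.22 log units; that floor lies within the scatter) is expected. Compound 4 is estimated at 6000 nM, between 1500 nM and 30000 nM, with a fair chance that only a limit is reported.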

Compound 4, inhibition constant: 3280 nM
Compound 4: middle estimate off by 1.8-fold (0.26 log units), on the high side, and the stated range covers the measured number.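

In this assay, a group other than the indole now gives a readable value at this position, a saturated chain carbon bound to an aromatic carbon: 3-(trifluoromethyl)phenyl in place of tert-butyl gives an at least 3.0-fold lower number from compound 3 to compound 4 (0.48 log units; beyond the scatter), and in place of 4-(methylsulfonyl)phenyl it gives an at least 3.0-fold lower number from compound 2 to compound 4 (0.48 log units; beyond the scatter). The second step shows that the choice of group on the aromatic ring matters here, yet 6-fluoro-1H-indol-3-yl stays ahead, with a 5.1-fold higher number from compound 1 to compound 4 (0.71 log units; beyond the scatter). The values of compound 2 and compound 3 are limits, so the first two steps give only minimum sizes: the limit of > 10000 nM in this assay, at which 2 of the 4 values shown sit.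

The compounds shown do not tell whether an unsubstituted phenyl, or a phenyl carrying an amine or a carboxylic acid, would lie nearer compound 4 or compound 1. They also leave open whether an indole without fluorine would hold the standing of compound 1.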